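Urea to benzamide on the anilide arm of compound 1

This account rests on a few compounds, and the source may have more. Where it says the series, first, only, none or still open, it means among the compounds named here.

Compound 1 `COc1cc(-c2nn(-c3cccc(NC(=O)Nc4ccc(Cl)c(Cl)c4)c3)cc2-c2ccncc2)ccc1Cl` carries a diaryl urea on the pyrazole-bound aniline. In a functional assay on SF-295 cells (Homo sapiens) for inhibition, read by sulforhodamine B assay, with a stated time of 48 h (on this read-out lower numbers stand for stronger inhibition and higher numbers for weaker inhibition), compound 1 gives 690 nM, the higher of the two numbers reported so far. Compound 3 `O=C(Nc1cccc(-n2cc(-c3ccncc3)c(-c3ccc(Cl)c(O)c3)n2)c1)Nc1cc(C(F)(F)F)cc(C(F)(F)F)c1` gives 620 nM, which sits within the usual scatter of the value for compound 1. In this assay compound 2 `O=C(Nc1cccc(-n2cc(-c3ccncc3)c(-c3ccc(Cl)c(O)c3)n2)c1)Nc1ccc(Cl)c(Cl)c1` gives "not determined" (no result reported), so no number is available for it.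

Compound 4 `COc1cc(-c2nn(-c3cccc(NC(=O)c4ccccc4)c3)cc2-c2ccncc2)ccc1Cl` replaces the urea with a simple benzamide: phenyl in place of (3,4-dichlorophenyl)amino on a carbonyl carbon. For the measured compounds named here, no directly comparable pair exists among the measured compounds. The step from compound 1 to compound 4 is expected to be a 3.6-fold higher number from compound 1 to compound 4 (0.56 log units; beyond the scatter), towards weaker inhibition, beyond the scatter. Compound 4 is estimated at 2500 nM, within 800 nM to 8000 nM.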

Compound 4, half-maximal inhibitory concentration: 340 nM
Compound 4: middle estimate off by 7.4-fold (0.87 log units), on the high side; measured number outside the range, below it.
By their numbers in this assay, from the lowest: compounds 4, 3 and 1 (each within the scatter of the next, the first and the last beyond it).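

In this assay the urea-to-benzamide change gives a 2.0-fold lower number from compound 1 to compound 4 (0.31 log units; beyond the scatter), a modest step, so the (3,4-dichlorophenyl)amino group on this carbonyl carbon is not required for inhibition at this level. Plain phenyl, with neither chlorine nor the urea's extra donor, is tolerated here and gives the lower number. No measured property of either group is available to account for the step. From the compounds shown here alone, it remains open whether a 3,4-dichlorobenzoyl group, which would restore both chlorines without the urea nitrogen, lowers the number further or raises it.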